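This account rests on a few compounds, and the source may have more. Where it says the series, first, only, none or still open, it means among the compounds named here.

Four compounds here share one core and differ only in the group on a saturated ring carbon of a four-membered non-aromatic ring with 1 nitrogen. In a functional assay on MCF7 cells (Homo sapiens) for antiproliferative activity, read by MTT assay, with stated times of 24 h and 72 h (on this read-out lower numbers stand for stronger inhibition and higher numbers for weaker inhibition), compound 1 (`COc1cc(N2C(=O)[C@@H](Oc3ccccc3)[C@H]2c2ccc3ccccc3c2)cc(OC)c1OC`) gives 282000 nM while compound 2 (`COc1cc(N2C(=O)[C@@H](Oc3ccccc3)[C@H]2c2cccc3ccccc23)cc(OC)c1OC`) gives 53000 nM and compound 3 (`COc1ccc([C@@H]2[C@H](Oc3ccccc3)C(=O)N2c2cc(OC)c(OC)c(OC)c2)cc1[N+](=O)[O-]`) gives 69000 nM on the same scale. Compound 3 thus stands level with compound 2, and both have a clearly lower number than compound 1.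

Compound 4 (`COc1cc(N2C(=O)[C@@H](Oc3ccccc3)[C@H]2c2ccc([S+](C)[O-])cc2)cc(OC)c1OC`) has not been measured yet. Its change from compound 3 is a group of 9 heavy atoms (7 carbon, 1 oxygen, 1 sulfur; one six-membered aromatic ring of carbon only) in place of a group of 11 heavy atoms (7 carbon, 1 nitrogen, 3 oxygen; one six-membered aromatic ring of carbon only), on a saturated ring carbon and it falls on that same ring carbon. Within the data shown here, no tested compound carries the entering group, so the only guide is how far exchanges at this carbon have moved the number. The two larger measured steps are a 5.3-fold lower number from compound 1 to compound 2 (0.73 log units; beyond the scatter) and a 4.1-fold lower number from compound 1 to compound 3 (0.61 log units; beyond the scatter) and both are modest, while the remaining one, a 1.3-fold higher number from compound 2 to compound 3 (0.11 log units; within the scatter) stays within the scatter. On that evidence, no step beyond the scatter is expected in this assay although a modest one in either direction remains possible. The expected step is a 1.3-fold higher number from compound 3 to compound 4 (0.12 log units; within the scatter) as an estimate only. For compound 4 the estimated value is 90000 nM with an expected range from 30000 nM to 250000 nM until a measurement is available.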

Compound 4, half-maximal inhibitory concentration: 20000 nM
The estimate for compound 4 lay 4.5-fold (0.65 log units) above the measured number; the whole stated range lies above it.
By their numbers in this assay, from the lowest: compound 4; then compounds 2 and 3 (each within the scatter of the next); then compound 1.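

The sulfur-bearing group on the saturated ring carbon gives the strongest inhibition of the four compounds in this assay, with a 3.5-fold lower number from compound 3 to compound 4 (0.54 log units; beyond the scatter), a 2.7-fold lower number from compound 2 to compound 4 (0.42 log units; beyond the scatter) and a 14-fold lower number from compound 1 to compound 4 (1.15 log units; beyond the scatter). Among these compounds, these steps show that this carbon can do more than the two naphthyl groups and the 4-methoxy-3-nitrophenyl group revealed: the step from compound 1 is the first large one here, and compound 4 is the first to move clearly below the level shared by compound 2 and compound 3. No measurement shown accounts for the gain, so the data give no reason for it.

From the compounds shown here alone, it remains open whether the sulfur-bearing group itself matters or any suitably substituted single benzene ring would do equally well, and a plain phenyl group would help to separate these possibilities. Going by these compounds, how a phenyl ring carrying an amine or a carboxylic acid would compare at this carbon also remains open, as does whether the gain would hold with a group other than phenoxy on the neighbouring ring atom.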